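This account rests on a few compounds, and the source may have more. Where it says the series, first, only, none or still open, it means among the compounds named here.

Measured so far in a functional assay on HeLa cells (Homo sapiens) for antiproliferative activity, read by CCK-8 assay, with a stated time of 72 h, tested at 8 uM; a lower number here means a weaker effect, a higher number a stronger effect of the compound at the concentration tested:
compound 1, `COc1ccc(N2CCN(C(=S)SCc3ccc(C(=O)Nc4ccccc4N)cc3)CC2)cc1`, gives 52.3%
compound 2, `Nc1ccccc1NC(=O)c1ccc(CSC(=S)N2CCN(c3cccnc3)CC2)cc1`, gives 72.5%
compound 3, `N#Cc1ccc(N2CCN(C(=S)SCc3ccc(C(=O)Nc4ccccc4N)cc3)CC2)cc1`, gives 70.6%

Compound 3 stands second highest of these three numbers. Its closest neighbour lies within the scatter, a number 1.9 percentage points lower from compound 2 to compound 3 (within the scatter), while its furthest neighbour lies well beyond it, a number 18.3 percentage points higher from compound 1 to compound 3 (beyond the scatter).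

Compound 4, `Cc1ccc(N2CCN(C(=S)SCc3ccc(C(=O)Nc4ccccc4N)cc3)CC2)cc1`, has not been measured. It differs from compound 3 in one place: methyl in place of cyano on an aromatic carbon. Of the measured steps, the one that bears most on this is the change at the same place, a number 18.3 percentage points higher from compound 1 to compound 3 (beyond the scatter), a modest rise when cyano replaced methoxy. The other two steps swap the whole ring on the amine nitrogen: a number 20.2 percentage points higher from compound 1 to compound 2 (beyond the scatter) and a number 1.9 percentage points lower from compound 2 to compound 3 (within the scatter). Within the data shown here, no measured compound carries methyl at this place, so the direction for methyl is not fixed by the data; the one change at this place moved the number modestly, and methyl resembles neither group that was measured.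

Compound 4 is therefore expected to give about 60%, within a range from 45% to 75%. The step this expectation implies is a number 10.6 percentage points lower from compound 3 to compound 4 (beyond the scatter), a small expected fall that may well stay within the scatter.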

Compound 4, a percentage reported as inhibition, at one concentration (the size of the read-out at that concentration, not a potency): 24%
Compound 4: middle estimate off by 36 percentage points, on the high side, and the stated range ends above it.
By their numbers in this assay, from the lowest: compound 4; then compound 1; then compounds 3 and 2 (each within the scatter of the next).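

In this assay, among these compounds, the group at this place on the aromatic ring matters more than the earlier compounds could show: methyl in place of cyano gives a number 46.6 percentage points lower from compound 3 to compound 4 (beyond the scatter) and is a far larger change than the one step previously seen here. Methyl also falls short of methoxy, with a number 28.3 percentage points lower from compound 1 to compound 4 (beyond the scatter) at the same place, and the swap of the whole pyridin-3-yl ring for 4-methylphenyl gives a number 48.5 percentage points lower from compound 2 to compound 4 (beyond the scatter), which leaves compound 4 lowest of the four, with all three of its steps beyond the scatter. No measurement shown accounts for this drop.

The compounds shown leave open whether the low number is particular to methyl or would also appear with an ethyl group or a longer chain at this place. They also leave open where other replacements, such as a chlorine atom, a trifluoromethyl group, a hydroxyl group or an amine, would fall among these values, and each value here describes a single tested concentration rather than a potency.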